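Lactam cap swap: aryl to benzyl on the hydroxamate series

The source may report more compounds than this note shows. Statements on the series, on what has been measured and on what is new or still open speak of the compounds shown alone.

Compound 1 `O=C(NO)c1ccc(NC2CCN(c3ccc(Cl)c(Cl)c3)C2=O)cc1` and compound 2 `CS(=O)(=O)c1ccc(N2CCC(Nc3ccc(C(=O)NO)cc3)C2=O)cc1` share a core. In an assay on isolated protein for inhibition of protein deacetylase HDAC6 (Homo sapiens) (on this read-out lower numbers stand for stronger inhibition and higher numbers for weaker inhibition), compound 1 gives 63 nM, and compound 2 gives 140 nM; compound 1 holds the lower of the two numbers, and its gap to compound 2 lies beyond the scatter. Compound 3 `O=C(NO)c1ccc(NC2CCN(Cc3ccccc3)C2=O)cc1` is not yet measured. It differs from compound 1 by benzyl in place of 3,4-dichlorophenyl on an amide-type nitrogen in a ring. For the measured compounds named here, no measured pair shows this change, so the expected step is a 1.7-fold higher number from compound 1 to compound 3 (0.24 log units; within the scatter), a modest weakening that may still fall within the scatter. Compound 3 is estimated at 110 nM in this assay, with a range from 35 nM to 350 nM.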

Compound 3, half-maximal inhibitory concentration: 510 nM
Estimate against measurement, compound 3: 4.6-fold (0.67 log units) below; measured number outside the range, above it.
By their numbers in this assay, from the lowest: compound 1; then compound 2; then compound 3.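

In this assay the substituent on the amide-type nitrogen in a ring matters: benzyl in place of 3,4-dichlorophenyl gives an 8.1-fold higher number from compound 1 to compound 3 (0.91 log units; beyond the scatter) at this position. Both groups carry one six-membered aromatic ring of carbon only and no hydrogen-bond donors or acceptors, so those counts do not separate them. No measurement at hand accounts for the step.

A plain phenyl or a 3,4-dichlorobenzyl on this nitrogen would separate the effect of the carbon link from that of the two chlorine atoms. The compounds shown leave that split open.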